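A Sulfonyl Replaces a Carbonyl on the Ring Nitrogen

This account rests on a few compounds, and the source may have more. Where it says the series, first, only, none or still open, it means among the compounds named here.

Of the compounds shown here, two sharing one core have so far been measured in a functional assay on NCI-H1975 cells (Homo sapiens) for inhibition, read by sulforhodamine B assay, tested at 10 uM; a higher number here means more inhibition at the concentration tested (going by the name of the read-out), a lower number less inhibition. Compound 1 `CN1CCN(c2ccc(C3=NN(C(=O)CCCl)C(c4ccc(N(C)C)cc4)C3)cc2)CC1` gives -0.2% in this assay, while compound 2 `CN1CCN(c2ccc(C3=NN(C(=O)/C=C/c4ccccc4)C(c4ccc(N(C)C)cc4)C3)cc2)CC1` gives 81%. Among the compounds with values here, the single measured step, a number 81.2 percentage points higher from compound 1 to compound 2 (beyond the scatter), shows how strongly the group on the ring nitrogen decides the read-out. Within the data shown here, compound 2 thus stands highest of the two numbers, with compound 1 as its only neighbour, beyond the scatter below it.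

Compound 3 `Cc1ccc(S(=O)(=O)N2N=C(c3ccc(N4CCN(C)CC4)cc3)CC2c2ccc(N(C)C)cc2)cc1` differs from compound 2 in one place: (4-methylphenyl)sulfonyl in place of (2-phenylethenyl)carbonyl on an amine nitrogen in a ring. Among the measured compounds shown here, no measured step exchanges a carbonyl-linked group for a sulfonyl-linked one, so the only guide is a number 81.2 percentage points higher from compound 1 to compound 2 (beyond the scatter), which tells that altering this group can shift the read-out across almost the whole range. A downward step is therefore expected, but its size remains uncertain. The estimate for compound 3 in this assay is 40%, ranging from 0% to 85%. This estimate means an expected step of a number 41 percentage points lower from compound 2 to compound 3 (beyond the scatter).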

Compound 3, a percentage reported as inhibition, at one concentration (the size of the read-out at that concentration, not a potency): 38.1%
Beside the measured number, compound 3's estimate is 1.9 percentage points above it; the range from low to high includes it.
By their numbers in this assay, from the lowest: compound 1; then compound 3; then compound 2.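

In this assay, the step of a number 42.9 percentage points lower from compound 2 to compound 3 (beyond the scatter) shows that the (4-methylphenyl)sulfonyl group does not retain the full read-out of the (2-phenylethenyl)carbonyl group, while the step of a number 38.3 percentage points higher from compound 1 to compound 3 (beyond the scatter) shows that it still stands well clear of the (2-chloroethyl)carbonyl group. The group on this ring nitrogen therefore gives an intermediate level among these three compounds, not just a high or a near-zero read-out. The two groups exchanged from compound 2 to compound 3 match in heavy atoms, in their six-membered aromatic ring and in double bonds outside aromatic rings, so these counts alone do not fix the read-out here, and no supporting data bear on why the numbers differ.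

The compounds shown leave open whether the lower read-out of compound 3 goes with the sulfonyl link or with the replacement of 2-phenylethenyl by 4-methylphenyl, as both change together in this step. A (2-phenylethenyl)sulfonyl group or a (4-methylphenyl)carbonyl group on the same nitrogen would separate these two changes.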